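A few compounds are considered here, and "the series" means these few. Any claim that something is new, unique, unknown or untested is made for them only; others in the source may bear on it.

Measured compounds:
- Compound 1 `COc1ccc(CNC(=O)c2nc(-c3ccc(F)cc3)n(CC[C@@H](O)C[C@@H](O)CC(=O)O)c2C2CC2)cc1F` gives 890 nM in a functional assay on L6 cells (Rattus norvegicus) for inhibition, read by scintillation counting, with a stated time of 3 h; a higher number here means a weaker inhibitor, a lower number a stronger inhibitor.
- Compound 2 `COc1cccc(CNC(=O)c2nc(-c3ccc(F)cc3)n(CC[C@@H](O)C[C@@H](O)CC(=O)O)c2C2CC2)c1` gives 538 nM in this assay.
- Compound 3 `O=C(O)C[C@H](O)C[C@H](O)CCn1c(-c2ccc(F)cc2)nc(C(=O)NCc2ccc(F)c(F)c2)c1C1CC1` gives 2780 nM in this assay.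

Compound 3 gives the highest number of the three, so it is the weakest inhibitor among them. The three compounds share one core and differ only in the aromatic ring on the saturated chain carbon bound to an amide-type nitrogen. Swapping that ring moves the number modestly: a 1.7-fold lower number from compound 1 to compound 2 (0.22 log units; within the scatter), a 3.1-fold higher number from compound 1 to compound 3 (0.49 log units; beyond the scatter), and a 5.2-fold higher number from compound 2 to compound 3 (0.71 log units; beyond the scatter).

Compound 4 `CN(C)S(=O)(=O)c1ccc(CNC(=O)c2nc(-c3ccc(F)cc3)n(CC[C@@H](O)C[C@@H](O)CC(=O)O)c2C2CC2)cc1` is not yet measured. It differs from compound 3 in the same place: 4-(dimethylsulfamoyl)phenyl in place of 3,4-difluorophenyl on a saturated chain carbon bound to an amide-type nitrogen. All three measured steps bear on this change, since each replaces the ring at that position, and each stayed within a modest span. Because of a 5.2-fold higher number from compound 2 to compound 3 (0.71 log units; beyond the scatter) and a 3.1-fold higher number from compound 1 to compound 3 (0.49 log units; beyond the scatter), compound 3 sits at the weak end, so a new ring seems more likely to lower the number than to raise it further. A modest step downward in this assay is expected, with the estimated step being a 3.1-fold lower number from compound 3 to compound 4 (0.49 log units; beyond the scatter). Compound 4 is therefore estimated at 900 nM, within a range from 300 nM to 3000 nM.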

Compound 4, half-maximal inhibitory concentration: > 100000 nM
Compound 4: only a limit was reported; the forecaster's own chance of this, stated with the estimate: 5%; middle value at least 110-fold (2.04 log units) away from the limit.
By their numbers in this assay, from the lowest: compounds 2 and 1 (each within the scatter of the next); then compound 3. At a limit, above all of these: compound 4.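

For compound 4, this assay gives only a limit and not a number: the limit of > 100000 nM in this assay, at which 1 of the 4 values shown sits.

Among the compounds shown, the ring on a saturated chain carbon bound to an amide-type nitrogen can matter far more than the earlier modest steps revealed: placing 4-(dimethylsulfamoyl)phenyl there gives an at least 35-fold higher number from compound 3 to compound 4 (1.55 log units; beyond the scatter), an at least 180-fold higher number from compound 2 to compound 4 (2.26 log units; beyond the scatter) and an at least 110-fold higher number from compound 1 to compound 4 (2.05 log units; beyond the scatter), all of them large. The position therefore does not treat every ring alike, and the three rings carrying only methoxy or fluoro groups do not predict the outcome for this one, which adds heavy atoms and hydrogen-bond acceptors relative to 3,4-difluorophenyl.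

From the compounds shown here alone, whether the loss follows the sulfonyl unit itself or the two methyl groups on its nitrogen stays open, and a ring carrying an unsubstituted sulfonamide or a methylsulfonyl group would separate the two. Also open, going by these compounds, is how a ring carrying an amine or a carboxylic acid would read in this assay, so the limits of what this position accepts remain only roughly drawn.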